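Aryl group changes on a shared core and cell growth

The source may report more compounds than this note shows. Statements on the series, on what has been measured and on what is new or still open speak of the compounds shown alone.

Compound 1 `CCC1=C(O)c2c(oc(-c3ccc(C)cc3)cc2=O)C(CC)(CC)C1=O` gives 39.2 uM in a functional assay on KB cells (Homo sapiens) for antiproliferative activity, read by sulforhodamine B assay, with a stated time of 3 days; on this read-out higher numbers stand for an effect only at larger amounts of compound and lower numbers for an effect already at smaller amounts.
Compound 2 `CCCc1ccc(-c2cc(=O)c3c(o2)C(CC)(CC)C(=O)C(CC)=C3O)cc1` reaches only > 53 uM in this assay, a limit of the assay rather than a number.
Compound 3 `CCC1=C(O)c2c(oc(-c3cccc(OC)c3)cc2=O)C(CC)(CC)C1=O` gives 13.3 uM in this assay.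

Compound 3 therefore stands lowest of the two numbers obtained; its nearest neighbour is compound 1, separated by a 2.9-fold lower number from compound 1 to compound 3 (0.47 log units; beyond the scatter). Compound 4 `CCC1=C(O)c2c(oc(-c3ccc(OC)cc3C)cc2=O)C(CC)(CC)C1=O` differs from compound 3 in one place: 4-methoxy-2-methylphenyl in place of 3-methoxyphenyl on an aromatic carbon. The steps of a 2.9-fold lower number from compound 1 to compound 3 (0.47 log units; beyond the scatter) and an at least 3.9-fold lower number from compound 2 to compound 3 (0.60 log units; beyond the scatter) bear on this change, both favouring 3-methoxyphenyl, while the limit of > 53 uM in this assay, at which 1 of the 3 values shown sits, leaves compound 2 undefined. The 4-methoxy-2-methylphenyl of compound 4 resembles the 4-methylphenyl of compound 1 more than the 3-methoxyphenyl of compound 3, so a modestly higher number is expected, a 1.9-fold higher number from compound 3 to compound 4 (0.27 log units; within the scatter). Compound 4 is estimated at 25 uM, between 8 uM and 60 uM.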

Compound 4, concentration for half-maximal effect: 20.9 uM
The estimate for compound 4 lay 1.2-fold (0.08 log units) above the measured number; measured number inside the range.
By their numbers in this assay, from the lowest: compounds 3, 4 and 1 (each within the scatter of the next, the first and the last beyond it). At a limit, above all of these: compound 2.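

Compound 4 blurs the contrast between compound 1 and compound 3 in this assay: a 1.6-fold higher number from compound 3 to compound 4 (0.20 log units; within the scatter) and a 1.9-fold lower number from compound 1 to compound 4 (0.27 log units; within the scatter) both stay within the scatter, so the 4-methoxy-2-methylphenyl group cannot be told apart from either neighbouring aryl group at this position. Against the 4-propylphenyl group the change does register, with an at least 2.5-fold lower number from compound 2 to compound 4 (0.40 log units; beyond the scatter). That step is only a floor, and compound 2 stands at a limit of the assay, not a number: the limit of > 53 uM in this assay, at which 1 of the 4 values shown sits.

On these data alone, it remains open whether the methyl group of the 4-methoxy-2-methylphenyl group matters on its own. As far as these compounds go, how a phenyl group carrying an amine or a carboxylic acid would behave at this position also remains open.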